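The compounds below may be only part of what the source reports. "The series", "measured", "known", "first", "only" and "open" are said of these compounds alone.

Compound 2 `O=C(Nc1ccc(Nc2ncnc3c2OCCN3)cc1)Nc1ccc(C(F)(F)F)cc1` is the weaker-looking of the two measured compounds on paper, though its position needs care: in an assay on isolated protein for inhibition of proto-oncogene tyrosine-protein kinase receptor Ret (Homo sapiens), read by 33P incorporation, with stated times of 15 min and 40 min (a lower number here means a stronger inhibitor, a higher number a weaker inhibitor), compound 2 gives 306 nM, while compound 1 `O=C(Nc1ccc(Nc2ncnc3c2OCCN3)cc1)Nc1ccc(Cl)c(C(F)(F)F)c1` gives 177 nM in this assay, and the two values lie within the scatter of each other, so no order between them can be claimed. Compound 3 `COc1cccc(NC(=O)Nc2ccc(Nc3ncnc4c3OCCN4)cc2)c1` shares the core of compound 2 and differs from it in one place: 3-methoxyphenyl in place of 4-(trifluoromethyl)phenyl on an amide-type nitrogen. Going by the values given here, no measured pair in this set shows what such a change does, so the expectation for compound 3 rests only on the two values above and on the change itself. Since both measured compounds carry a trifluoromethyl-bearing ring at this position, its loss is taken here as a step expected to weaken inhibition modestly, beyond the scatter, as expressed by a 2.6-fold higher number from compound 2 to compound 3 (0.42 log units; beyond the scatter). On that basis compound 3 is estimated to give 800 nM in this assay, with a plausible range from 250 nM to 3000 nM.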

Compound 3, half-maximal inhibitory concentration: 6810 nM
Estimate against measurement, compound 3: 8.5-fold (0.93 log units) below, outside the stated range (above it).
By their numbers in this assay, from the lowest: compounds 1 and 2 (each within the scatter of the next); then compound 3.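

Going by these compounds alone, with the shared core unchanged, 3-methoxyphenyl in place of 4-(trifluoromethyl)phenyl on an amide-type nitrogen gives in this assay the first step that can be read at this position: a 22-fold higher number from compound 2 to compound 3 (1.35 log units; beyond the scatter) and it is a large one. The earlier pair could not show this, as both of its members carry a trifluoromethyl-bearing ring here and their values lie within the scatter of each other. The result shows that this position is far from indifferent to the group it carries, and that this exchange costs much more inhibition than those two values alone could suggest, while nothing at hand bears on why the step is so large.

The single step changes both the substituent and its printed place on the ring, so the compounds shown do not separate the loss of trifluoromethyl from the move to a different place. Going by these compounds, whether 4-methoxyphenyl or 3-(trifluoromethyl)phenyl would stay close to compound 2 or fall toward compound 3 remains open, as does the outcome for a ring bearing a dimethylamino group or a carboxylic acid.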